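Removing one chloro from the dichlorobenzyl sulfonamide series

A few compounds are considered here, and "the series" means these few. Any claim that something is new, unique, unknown or untested is made for them only; others in the source may bear on it.

Measured compounds:
Compound 1, `O=S(=O)(NCCCCNCc1ccc(Br)cc1)c1cc(C(F)(F)F)cc(C(F)(F)F)c1`: 1600 nM
Compound 2, `O=S(=O)(NCCCNCc1ccc(Cl)c(Cl)c1)c1cc(C(F)(F)F)cc(C(F)(F)F)c1`: 4700 nM
Compound 3, `COc1cccc(CNCCCNS(=O)(=O)c2cc(C(F)(F)F)cc(C(F)(F)F)c2)c1`: 10000 nM

All three were tested in a functional assay on HT-29 cells (Homo sapiens) for inhibition, read by MTT assay, with a stated time of 72 h; on this read-out lower numbers stand for stronger inhibition of growth and higher numbers for weaker inhibition of growth. Compound 2 holds the second highest number of the three; compound 3 sits nearest with a step of a 2.1-fold higher number from compound 2 to compound 3 (0.33 log units; beyond the scatter), and compound 1 furthest with a step of a 2.9-fold higher number from compound 1 to compound 2 (0.47 log units; beyond the scatter).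

Compound 4, `O=S(=O)(NCCCNCc1ccc(Cl)cc1)c1cc(C(F)(F)F)cc(C(F)(F)F)c1`, is not yet measured. It differs from compound 2 by hydrogen in place of chloro on an aromatic carbon, on an aromatic carbon of a six-membered aromatic ring of carbon only, ortho to a chloro group.

Within the data shown here, no measured step alters exactly this position. The nearest comparisons are the change from 3,4-dichlorophenyl to 3-methoxyphenyl, a 2.1-fold higher number from compound 2 to compound 3 (0.33 log units; beyond the scatter), and the change from the longer bromobenzyl chain to the dichlorobenzyl, a 2.9-fold higher number from compound 1 to compound 2 (0.47 log units; beyond the scatter). Compound 1, carrying a single halogen in the same position as the retained chloro, gives 1600 nM, which suggests one halogen suffices. A step of roughly a 1.3-fold lower number from compound 2 to compound 4 (0.13 log units; within the scatter) is therefore expected, most likely within the scatter and leaning toward a lower number. Compound 4 is estimated at 3500 nM, within 1500 nM to 8000 nM.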

Compound 4, concentration for 50% growth inhibition: 2800 nM
Compound 4: the middle estimate sits 1.3-fold (0.10 log units) above what was measured; low and high end bracket the measured number.
By their numbers in this assay, from the lowest: compounds 1, 4 and 2 (each within the scatter of the next, the first and the last beyond it); then compound 3.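

In this assay, the change from 3,4-dichlorophenyl to 4-chlorophenyl gives a 1.7-fold lower number from compound 2 to compound 4 (0.22 log units; within the scatter) and so shows that, at this aromatic carbon, hydrogen can take the place of the chloro without a step beyond the scatter. The 4-chlorophenyl group also gives a direct comparison with 3-methoxyphenyl, a 3.6-fold lower number from compound 3 to compound 4 (0.55 log units; beyond the scatter) and this step is beyond the scatter. The comparison with the bromobenzyl compound, a 1.8-fold higher number from compound 1 to compound 4 (0.24 log units; within the scatter) is also within the scatter, but that step changes both the halogen and the chain, so neither change can be read alone.

Nothing shown here explains why the chloro at this position can be replaced in this way. Going by these compounds, whether fluoro, methyl or nitrile on this same aromatic carbon would read differently stays open, as does an unsubstituted benzyl group.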